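The source may report more compounds than this note shows. Statements on the series, on what has been measured and on what is new or still open speak of the compounds shown alone.

In an ADME assay on MT4 cells (Homo sapiens) for cytotoxicity, read by MTT assay (on this read-out higher numbers stand for lower toxicity in this test and lower numbers for higher toxicity in this test), three compounds sharing one core have been measured. Compound 1 (`Cc1ccc(NC(=O)CSc2nncnc2-c2cccc3ccccc23)c(Br)c1`) gives 166000 nM, compound 2 (`O=C(CSc1nncnc1-c1cccc2ccccc12)Nc1ccccc1Br`) gives 87000 nM, and compound 3 (`O=C(CSc1nncnc1-c1cccc2ccccc12)Nc1ccccc1F`) gives 65000 nM. The data separate compound 3 from only one of the other two: there is a 2.6-fold lower number from compound 1 to compound 3 (0.41 log units; beyond the scatter), whereas a 1.3-fold lower number from compound 2 to compound 3 (0.13 log units; within the scatter). The remaining pair shows a 1.9-fold lower number from compound 1 to compound 2 (0.28 log units; within the scatter).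

Compound 4 (`O=C(CSc1nncnc1-c1cccc2ccccc12)N1CCc2ccccc2C1`) is still unmeasured. It differs from compound 3 by 1,2,3,4-tetrahydroisoquinolin-2-yl in place of (2-fluorophenyl)amino on a carbonyl carbon, with 1,2,3,4-tetrahydroisoquinolin-2-yl in place of (2-fluorophenyl)amino on a carbonyl carbon. Among the measured compounds shown here, no measured step makes this kind of replacement, since all three compounds keep the amino link and vary only its aromatic group. The steps are therefore a weak guide, though even the largest, a 2.6-fold lower number from compound 1 to compound 3 (0.41 log units; beyond the scatter), is modest. No clear shift beyond the scatter is expected in this assay, and the expected change is a 1.2-fold higher number from compound 3 to compound 4 (0.09 log units; within the scatter). The estimate for compound 4 is 80000 nM, with an expected range from 30000 nM to 200000 nM.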

Compound 4, half-maximal cytotoxic concentration: 13000 nM
The estimate for compound 4 lay 6.2-fold (0.79 log units) above the measured number; the whole stated range lies above it.
By their numbers in this assay, from the lowest: compound 4; then compounds 3, 2 and 1 (each within the scatter of the next, the first and the last beyond it).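

At this carbonyl carbon, 1,2,3,4-tetrahydroisoquinolin-2-yl gives the lowest number of the four in this assay, and so the highest toxicity in this test, with every step to it beyond the scatter (a 5.0-fold lower number from compound 3 to compound 4 (0.70 log units; beyond the scatter); a 6.7-fold lower number from compound 2 to compound 4 (0.83 log units; beyond the scatter); a 13-fold lower number from compound 1 to compound 4 (1.11 log units; beyond the scatter)). Compounds 1, 2 and 3 all keep the amino link and differ only on its aromatic group, whereas this change replaces the whole (2-fluorophenyl)amino group and leaves compound 4 without the hydrogen-bond donor. Nothing shown accounts for the lower number.

The change alters the donor count and the ring system together, so the compounds shown cannot separate the two. Going by these compounds, it remains open whether N-methyl-N-(2-fluorophenyl)amino, benzylamino or piperidin-1-yl at this carbon would give a number nearer that of compound 3 or that of compound 4.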